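This account rests on a few compounds, and the source may have more. Where it says the series, first, only, none or still open, it means among the compounds named here.

Three compounds built on one shared core set the scene. Compound 1 `C[C@H](Nc1ncnc2[nH]cnc12)c1nn(-c2cccnc2)c2cc(F)ccc12` carries pyridin-3-yl on an aromatic nitrogen, and in a functional assay on Hep 3B2 cells (Homo sapiens) for inhibition, read by sulforhodamine B assay, with a stated time of 72 h (a lower number here means a stronger inhibitor, a higher number a weaker inhibitor), compound 1 gives 34500 nM. Compound 2 `C[C@H](Nc1ncnc2[nH]cnc12)c1nn(-c2ccncc2)c2cc(F)ccc12` carries pyridin-4-yl there instead, and in this assay compound 2 gives 21400 nM. Compound 3 `C[C@H](Nc1ncnc2[nH]cnc12)c1nn(-c2ccccn2)c2cc(F)ccc12` carries pyridin-2-yl at the same place. For compound 3 the assay reports only a limit, > 40000 nM, and not a number. The moves among these three are small: a 1.6-fold lower number from compound 1 to compound 2 (0.21 log units; within the scatter), an at least 1.1-fold higher number from compound 1 to compound 3 (0.06 log units; that floor lies within the scatter), and an at least 1.8-fold higher number from compound 2 to compound 3 (0.27 log units; that floor lies within the scatter). For the measured compounds named here, compound 3 thus stands at the weak end of what has been measured, sitting at the limit of > 40000 nM in this assay, at which 1 of the 3 values shown sits, though no step separating it from the others exceeds the scatter.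

Compound 4 `C[C@H](Nc1ncnc2[nH]cnc12)c1nn(-c2cccc(F)c2)c2cc(F)ccc12` is the next step from compound 3: 3-fluorophenyl in place of pyridin-2-yl on an aromatic nitrogen. Going by the values given here, none of the measured steps involves a carbon-only ring entering; the three steps so far only exchange one pyridinyl for another and all stay within the scatter. On that basis no step beyond the scatter is expected in this assay, and the estimated move is an at least 1.3-fold lower number from compound 3 to compound 4 (0.12 log units; that floor lies within the scatter). Compound 4 is therefore expected to give about 30000 nM, with a range from 12000 nM to 60000 nM.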

Compound 4, half-maximal inhibitory concentration: > 40000 nM
Compound 4: no number, only a limit; the forecaster's own chance of this, stated with the estimate: 35%; middle value at least 1.3-fold (0.12 log units) from the limit.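

In this assay, the carbon-only 3-fluorophenyl ring does not bring compound 4 to a readable number: its value is a limit, as is that of compound 3, and the step between these two cannot be read. The readable steps are an at least 1.8-fold higher number from compound 2 to compound 4 (0.27 log units; that floor lies within the scatter) and an at least 1.1-fold higher number from compound 1 to compound 4 (0.06 log units; that floor lies within the scatter), so even this change of ring type, with no ring nitrogen left in the group on the aromatic nitrogen, shows no step beyond the scatter. Among the four compounds, a pyridinyl group is therefore not required to reach the weak end of the series, and a carbon-only ring bearing fluorine offers no readable gain there, with the limit now shared by a second compound: the limit of > 40000 nM in this assay, at which 2 of the 4 values shown sit.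

As far as these compounds go, it remains open how far apart compound 3 and compound 4 truly lie, and whether an unsubstituted phenyl ring would also end at the limit. Also open, from the compounds shown here alone, is whether an amine or a carboxylic acid on the ring at this position would move the number beyond the scatter.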